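The source may hold more compounds than are shown below. What is called first, only, known or untested is meant among the compounds shown, and "the series" means these compounds.

In a functional assay on Jurkat cells (Homo sapiens) for cytotoxicity, read by colorimetric assay, with a stated time of 72 h (a higher number here means a weaker inhibitor, a lower number a stronger inhibitor), two members of this series have been examined so far. Compound 1 (`OC[C@H](NC[C@H]1NC[C@H](O)[C@@H]1O)c1ccc(-c2ccsc2)cc1`) is recorded in this assay as "not active" (no number reported). Compound 2 (`C=CCOc1ccc([C@H](CO)NC[C@H]2NC[C@H](O)[C@@H]2O)cc1`) reaches only the limit of this assay, reported as > 200000 nM. Among the compounds with values here, compound 2 thus stands at the limit of > 200000 nM in this assay, at which 1 of the 2 values shown sits, and since compound 1 carries no number either, no step between measured compounds can be drawn from this series.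

Compound 3 (`OC[C@H](NC[C@H]1NC[C@H](O)[C@@H]1O)c1ccc(OCc2ccccc2)cc1`) has not yet been tested in this assay. It differs from compound 2 in one place: phenyl in place of vinyl on a saturated chain carbon bound to an oxygen on an aromatic ring. Nothing in the measured record points to a change beyond the usual scatter for such an exchange, and with both known compounds lacking a number, a step that the limit leaves unreadable from compound 2 to compound 3 is expected in this assay, that is, no real movement away from the limit. Compound 3 is therefore estimated at 250000 nM in this assay, within a range from 60000 nM to 1000000 nM, and it is expected that the result will most likely again be reported only as a limit rather than as a number.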

Compound 3, half-maximal inhibitory concentration: "not active" (no number reported)
No number was reported for compound 3; there is nothing to compare the estimate with.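

Within the data shown here, compound 3 is recorded in this assay as not active, with no number, so no step from compound 2 to compound 3 can be read. Compound 2 offers only a limit: the limit of > 200000 nM in this assay, at which 1 of the 3 values shown sits.

The compounds shown leave open whether any allyloxy or benzyloxy member of this series has a numerical cytotoxic potency in this assay.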